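This account rests on a few compounds, and the source may have more. Where it says the series, first, only, none or still open, it means among the compounds named here.

The compounds here share one core, differing only in the aromatic group attached to it. Compound 1 `COc1ccccc1-c1nccc2[nH]c(C(C)(C)O)cc12` carries a methoxy group on that aromatic ring. In an ADME assay on U2OS cells (Homo sapiens) for cytotoxicity (a lower number here means that less compound is tolerated, a higher number that more compound is tolerated), compound 1 gives "not determined" (no result reported), so its own standing on this read-out is simply unknown. Two relatives with the same core have been measured. Compound 2 `CC(C)(O)c1cc2c(-c3cc(C(F)(F)F)cc(C(F)(F)F)c3)nccc2[nH]1` gives 59800 nM in this assay, and compound 3 `CC(C)(O)c1cc2c(-c3ccc4ccccc4c3)nccc2[nH]1` gives 22500 nM in this assay. Both values sit at high concentrations, which means the cells tolerate a great deal of either compound.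

Compound 4 `CC(C)(O)c1cc2c(-c3ccccc3)nccc2[nH]1` is reached from compound 1 by a single change: hydrogen in place of methoxy on an aromatic carbon. With no number for compound 1, the step cannot be measured from the data; what can be said rests on compound 2 and compound 3, whose values show that this core is tolerated at high concentrations regardless of the attached group. The step from compound 1 to compound 4 in this assay is therefore expected to be small, within the usual scatter or at most a modest shift toward greater tolerance. Compound 4 is expected to give about 50000 nM in this assay, with a likely range from 18000 nM to 150000 nM.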

Compound 4, half-maximal cytotoxic concentration: 22200 nM
Beside the measured number, compound 4's estimate is 2.3-fold (0.35 log units) above it, and the stated range covers the measured number.
By their numbers in this assay, from the lowest: compounds 4 and 3 (each within the scatter of the next); then compound 2.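

In this assay compound 1 gives "not determined" (no result reported) and so the step to compound 4 cannot be read. The compounds shown leave open whether swapping the methoxy group of compound 1 for hydrogen changes how much compound the cells tolerate. Nothing shown here offers an explanation for the value of compound 4.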